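A Methylphenyl Variant Within an Oxazole Series

This account rests on a few compounds, and the source may have more. Where it says the series, first, only, none or still open, it means among the compounds named here.

Compound 1 `CCCc1nc(-c2ccccc2)c(CNCCN2CCN(c3ccccc3F)CC2)o1` and compound 2 `CCCc1nc(-c2ccccc2)c(CNCCCN2CCN(c3ccc(F)cc3)CC2)o1` share the same core and were both tested in an assay on HEK293 cells for inhibition of Voltage-dependent T-type calcium channel subunit alpha-1G (Homo sapiens), read by fluorescence, tested at 10 uM; on this read-out higher numbers stand for more inhibition at the one concentration tested (going by the name of the read-out) and lower numbers for less inhibition. In this assay compound 1 gives 46.5%, and compound 2 gives 62.5%. Compound 1 therefore stands at the lower of the two numbers, and its gap to compound 2 lies beyond the usual scatter of such measurements. Within the data shown here, the two compounds differ in more than one place, so their values show only that compound 2 inhibits more at this concentration, without pointing to any single change as the cause.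

Compound 3 `CCCc1nc(-c2ccccc2)c(CNCCN2CCN(c3ccc(C)cc3)CC2)o1` has not yet been measured in this assay. It differs from compound 1 by 4-methylphenyl in place of 2-fluorophenyl on an amine nitrogen in a ring. Among the measured compounds shown here, no pair of measured compounds isolates a change of this kind, so nothing in the data fixes its direction. The step from compound 1 to compound 3 is expected to be small, a number 3.5 percentage points higher from compound 1 to compound 3 (within the scatter), and may well fall within the scatter in either direction. For compound 3 the expected inhibition is 50%, with a range from 25% to 75%.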

Compound 3, a percentage reported as inhibition, at one concentration (the size of the read-out at that concentration, not a potency): 48.1%
Beside the measured number, compound 3's estimate is 1.9 percentage points above it; the measured number falls inside the stated range.
By their numbers in this assay, from the lowest: compounds 1 and 3 (each within the scatter of the next); then compound 2.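

In this assay, among these compounds, 4-methylphenyl in place of 2-fluorophenyl on an amine nitrogen in a ring gives a number 1.6 percentage points higher from compound 1 to compound 3 (within the scatter), the first step in this set that changes one place only. At this position, then, the two groups cannot be told apart at the one concentration tested, even though they differ both in the atoms they carry and in the ring position named by each group. Nothing in hand explains why this exchange leaves the read-out within the scatter.

Compound 2 differs from each of the other two compounds in more than one place, so the compounds shown cannot say what lies behind its number, and the effect of its longer chain remains unseparated from that of its 4-fluorophenyl group. Among the compounds shown here, it also remains open whether this position would respond to a more different group on the phenyl ring, such as a methoxy group, a nitrile or a carboxylic acid, since the one step available covers only a single pair of groups.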